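A sulfonylamino group in place of the benzothiazole

This account rests on a few compounds, and the source may have more. Where it says the series, first, only, none or still open, it means among the compounds named here.

Measured so far in an assay on isolated protein for inhibition of tyrosine-protein phosphatase non-receptor type 13 (Homo sapiens), read by spectrophotometry; on this read-out lower numbers stand for stronger inhibition and higher numbers for weaker inhibition:
Compound 1 `Cc1ccc(O)c(C(O)(C(F)(F)F)C(F)(F)F)c1` gives 454000 nM.
Compound 2 `O=C(COc1ccc2cc(C(O)(C(F)(F)F)C(F)(F)F)c(O)cc2c1)Nc1nc2ccccc2s1` gives 9900 nM.
Compound 3 `CCCNC(=O)COc1ccc2cc(C(O)(C(F)(F)F)C(F)(F)F)c(O)cc2c1` gives > 20000 nM, which is a limit of this assay rather than a number.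

Compound 2 holds the lower of the two numbers, with compound 1 far above it, well beyond the usual scatter. Compound 4 `Cc1ccc(S(=O)(=O)NNC(=O)COc2ccc3cc(C(O)(C(F)(F)F)C(F)(F)F)c(O)cc3c2)cc1` differs from compound 2 by ((4-methylphenyl)sulfonyl)amino in place of 1,3-benzothiazol-2-yl on an amide-type nitrogen. Going by the values given here, the one step that bears on this position is an at least 2.0-fold higher number from compound 2 to compound 3 (0.30 log units; that floor lies within the scatter), where a propyl chain replaced the aromatic group and the value reached (the limit of > 20000 nM in this assay, at which 1 of the 3 values shown sits). An aromatic ring stays in compound 4, but the group is changed, so a weakening is expected: compound 4 is estimated at 25000 nM, between 8000 nM and 80000 nM, a step of a 2.5-fold higher number from compound 2 to compound 4 (0.40 log units; beyond the scatter).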

Compound 4, half-maximal inhibitory concentration: 14900 nM
Compound 4: middle estimate off by 1.7-fold (0.22 log units), on the high side; measured number inside the range.
By their numbers in this assay, from the lowest: compounds 2 and 4 (each within the scatter of the next); then compound 1.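

In this assay, the new step reads a 1.5-fold higher number from compound 2 to compound 4 (0.18 log units; within the scatter), so ((4-methylphenyl)sulfonyl)amino serves this amide-type nitrogen as well as 1,3-benzothiazol-2-yl, within what the assay can tell apart. The value of compound 3 is a limit, not a number: the limit of > 20000 nM in this assay, at which 1 of the 4 values shown sits. The comparison with that propyl compound therefore gives only a floor, an at least 1.3-fold lower number from compound 3 to compound 4 (0.12 log units; that floor lies within the scatter), and does not show that an aromatic ring here matters.

Still open, on these data alone, is how a plain phenyl ring, a longer chain or a carboxylic acid in this place would read. Also open, as far as these compounds go, is whether the methyl on the new ring plays any part.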